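Saturating and shortening an ether chain: compound 3 to compound 4

A few compounds are considered here, and "the series" means these few. Any claim that something is new, unique, unknown or untested is made for them only; others in the source may bear on it.

Measured so far in an assay on THP-1 cells for inhibition of nuclear factor NF-kappa-B complex (Homo sapiens), with stated times of 2 h and 16 h; on this read-out higher numbers stand for weaker inhibition and lower numbers for stronger inhibition:
Compound 1 `CC(C)CCCOc1cccc(O)c1C(=O)/C=C/c1ccc(O)cc1` gives 11000 nM.
Compound 2 `COc1cccc(OCCC(C)(C)C)c1C(=O)/C=C/c1ccc(O)cc1` reaches only the limit of > 30000 nM.
Compound 3 `CC(C)=CCOc1cccc(O)c1C(=O)/C=C/c1ccc(O)cc1` likewise reaches only the limit of > 30000 nM.

Compound 3 therefore stands at the weak end of the shown numbers, and its value is a limit rather than a number, as is the value of compound 2 (the limit of > 30000 nM in this assay, at which 2 of the 3 values shown sit). For the measured compounds named here, the one measured step that touches it, an at least 2.7-fold higher number from compound 1 to compound 3 (0.43 log units; beyond the scatter), can only be sized as a lower bound due to the limit of > 30000 nM in this assay, at which 2 of the 3 values shown sit.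

Compound 4 `CC(C)COc1cccc(O)c1C(=O)/C=C/c1ccc(O)cc1` differs from compound 3 in one place: isopropyl in place of 2-methylprop-1-en-1-yl on a saturated chain carbon bound to an oxygen on an aromatic ring. This undoes the unsaturation that the step from compound 1 to compound 3 introduced, while also shortening the chain. The step to compound 4 is expected to bring the number back toward that of compound 1, estimated as an at least 1.5-fold lower number from compound 3 to compound 4 (0.17 log units; that floor lies within the scatter). Compound 4 is thus expected to give about 20000 nM in this assay, within 8000 nM to 60000 nM.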

Compound 4, half-maximal inhibitory concentration: 8000 nM
Compound 4: the middle estimate sits 2.5-fold (0.40 log units) above what was measured; the range from low to high includes it.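

In this assay, saturated chains at this ether position give measurable inhibition where the 2-methylprop-1-en-1-yl chain does not (an at least 3.7-fold lower number from compound 3 to compound 4 (0.57 log units; beyond the scatter)). That step can be sized only as a lower bound, due to a limit of the assay: the limit of > 30000 nM in this assay, at which 2 of the 4 values shown sit. Isopropyl and isopentyl on this saturated chain carbon cannot be told apart (a 1.4-fold lower number from compound 1 to compound 4 (0.14 log units; within the scatter)), so chain length among these saturated groups shows no effect here.

From the compounds shown here alone, how an amine or a carboxylic acid at the end of this chain would read stays open. So does a chain longer than the one in compound 1.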